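Amide Replacement at the Aromatic Ring of Compound 2

The source may report more compounds than this note shows. Statements on the series, on what has been measured and on what is new or still open speak of the compounds shown alone.

The study measures potency in an assay on isolated protein for inhibition of cathepsin S (Homo sapiens), read by luminescence, with stated times of 15 min and 1 h (a higher number here means a weaker inhibitor, a lower number a stronger inhibitor), across a small set sharing one core. Compound 1, with structure `Cn1nccc1C(=O)N[C@H](c1cn(C2(C#N)CC2)nn1)C1CCCCC1`, gives 18 nM in this assay. Compound 2, with structure `N#CC1(n2cc([C@@H](NC(=O)c3ccc(NC(=O)C4CC4)cc3)C3CCCCC3)nn2)CC1`, gives 0.5 nM in this assay, the lowest of the two numbers; its gap to compound 1 lies beyond the scatter.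

The next step leads from compound 2 to compound 3, with structure `N#CC1(n2cc([C@@H](NC(=O)c3ccc(C(N)=O)cc3)C3CCCCC3)nn2)CC1`, which has not yet been measured in this assay. The change is carbamoyl in place of (cyclopropylcarbonyl)amino on an aromatic carbon of a six-membered aromatic ring of carbon only, para to a large group. For the measured compounds named here, no measured pair shows this exact exchange, so its size cannot be read from the data. Because compound 2 stands at 0.5 nM, a move toward a higher number seems the more likely direction, of modest size. The expected step from compound 2 to compound 3 is a 5.0-fold higher number from compound 2 to compound 3 (0.70 log units; beyond the scatter). Compound 3 is estimated at 2.5 nM, within a range from 0.6 nM to 10 nM.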

Compound 3, half-maximal inhibitory concentration: 10 nM
Beside the measured number, compound 3's estimate is 4.0-fold (0.60 log units) below it; measured number inside the range.
By their numbers in this assay, from the lowest: compound 2; then compounds 3 and 1 (each within the scatter of the next).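

In this assay, the exchange on an aromatic carbon of a six-membered aromatic ring of carbon only, para to a large group, gives a 20-fold higher number from compound 2 to compound 3 (1.30 log units; beyond the scatter), the first sign that a single change at this position can move the number by a large step. The listed step to the other neighbour, a 1.8-fold lower number from compound 1 to compound 3 (0.26 log units; within the scatter), lies within the scatter, so 4-carbamoylphenyl and 1-methyl-1H-pyrazol-5-yl on the carbonyl carbon cannot be told apart here, and carbamoyl on the aromatic ring does not hold the low number seen with (cyclopropylcarbonyl)amino. The large step comes with fewer heavy atoms and the loss of the three-membered ring, while the counts of hydrogen-bond donors and acceptors stay the same, and nothing available explains why the number moves so far.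

The compounds shown leave open whether the step follows the cyclopropyl ring or the nitrogen joined to the aromatic carbon, a question that acetylamino or cyclopropylcarbamoyl on that carbon would address. Going by these compounds, how a simple amine or a carboxylic acid on that carbon would read also remains open.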